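Removing One Double Bond from a Long Chain

The source may report more compounds than this note shows. Statements on the series, on what has been measured and on what is new or still open speak of the compounds shown alone.

In a functional assay on HeLa cells (Homo sapiens) for cytotoxicity, read by MTT assay, with a stated time of 24 h (a higher number here means a weaker inhibitor, a lower number a stronger inhibitor), compound 2 `CCCCCCCC/C=C\CCCCCCCC(=O)Nc1nnc(S[C@@H]2O[C@H](COC(C)=O)[C@H](OC(C)=O)[C@H](OC(C)=O)[C@H]2OC(C)=O)s1` gives 54400 nM, level with compound 1 `CCCCCCCCCCCC(=O)Nc1nnc(S[C@@H]2O[C@H](COC(C)=O)[C@H](OC(C)=O)[C@H](OC(C)=O)[C@H]2OC(C)=O)s1` at 51900 nM. Compound 3 `CCCCCCCCCC(=O)Nc1nnc(S[C@@H]2O[C@H](CO)[C@H](O)[C@H](O)[C@H]2O)s1` sits lower at 25900 nM, a gap from compound 2 that lies beyond the scatter. Compound 4 `CCCCCCCCCCCCCCCCCC(=O)Nc1nnc(S[C@@H]2O[C@H](COC(C)=O)[C@H](OC(C)=O)[C@H](OC(C)=O)[C@H]2OC(C)=O)s1` differs from compound 2 in one place: decyl in place of dec-1-en-1-yl on a saturated chain carbon, seven bonds along the chain from a carbonyl carbon. Decyl stands in place of dec-1-en-1-yl, on a saturated chain carbon, seven bonds along the chain from a carbonyl carbon. For the measured compounds named here, only one measured step bears on this: butyl gave way to dec-1-en-1-yl at that same place, and the result was a 1.0-fold higher number from compound 1 to compound 2 (0.02 log units; within the scatter). No change beyond the scatter is therefore expected, and the estimated step is a 1.0-fold lower number from compound 2 to compound 4 (0.02 log units; within the scatter). For compound 4 the estimated value is 52000 nM, with an expected range of 30000 nM to 90000 nM.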

Compound 4, half-maximal inhibitory concentration: 97500 nM
For compound 4 the middle estimate is 1.9-fold (0.27 log units) below the measured one; the measured number lies above the stated range.
By their numbers in this assay, from the lowest: compounds 3, 1, 2 and 4 (each within the scatter of the next, the first and the last beyond it).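

In this assay decyl in place of dec-1-en-1-yl gives a 1.8-fold higher number from compound 2 to compound 4 (0.25 log units; within the scatter) so at this place, on a saturated chain carbon, the double bond can go without a shift past the scatter. Hexyl in place of hydrogen on a saturated chain carbon gives a 1.9-fold higher number from compound 1 to compound 4 (0.27 log units; within the scatter) so this extension of the saturated chain also stays inside the scatter. From the compounds shown here alone, whether an amine, a carboxylic acid or a longer chain in place of decyl would shift the number remains open. No supporting measurement explains these steps.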